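Cytotoxicity of a Shared Core at the Assay Limit

The source may hold more compounds than are shown below. What is called first, only, known or untested is meant among the compounds shown, and "the series" means these compounds.

Compound 1 `CCC/C=C/C(=O)Nc1cccc(Oc2nc(Nc3cccc(C#N)c3)nc3c2CSCC3)c1`: > 50000 nM
Compound 2 `CC(C)=CC(=O)Nc1cccc(Oc2nc(Nc3cccc(C#N)c3)nc3c2CSCC3)c1`: > 50000 nM
Compound 3 `CCC/C=C/C(=O)Nc1cccc(Oc2nc(Nc3ccc(OC)nc3)nc3c2CSCC3)c1`: > 50000 nM

In an ADME assay on L02 cells (Homo sapiens) for cytotoxicity, read by MTT assay, with a stated time of 72 h (on this read-out lower numbers stand for stronger inhibition and higher numbers for weaker inhibition), compound 1 reaches only a limit, not a number. The same holds for compound 2 and for compound 3, so that the limit of > 50000 nM in this assay, at which 3 of the 3 values shown sit, is the whole of the evidence. The change 2-methylprop-1-en-1-yl in place of pent-1-en-1-yl on a carbonyl carbon therefore gives a step that the two limits leave unreadable from compound 1 to compound 2. The change 6-methoxypyridin-3-yl in place of 3-cyanophenyl on a nitrogen on an aromatic ring gives a step that the two limits leave unreadable from compound 1 to compound 3.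

Compound 4 `COc1ccc(Nc2nc3c(c(Oc4cccc(NC(=O)C=C(C)C)c4)n2)CSCC3)cn1` differs from compound 3 by 2-methylprop-1-en-1-yl in place of pent-1-en-1-yl on a carbonyl carbon, the same change as from compound 1 to compound 2. Since that change sat at the limit on both sides, compound 4 is expected to sit there as well, with a step that the limit leaves unreadable from compound 3 to compound 4 as the estimated step. Compound 4 is estimated at 80000 nM in this assay, between 40000 nM and 200000 nM, most likely again as a limit.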

Compound 4, half-maximal inhibitory concentration: > 50000 nM
Compound 4: no number, only a limit (the forecaster's own chance of this, stated with the estimate: 90%); the middle value is on the limit's open side.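

Compound 4 also gives only a limit in this assay, so its steps from compound 3 and compound 2 cannot be read: the limit of > 50000 nM in this assay, at which 4 of the 4 values shown sit.

The compounds shown leave open whether either change alters the read-out in this assay at all.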